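The source may hold more compounds than are shown below. What is called first, only, known or untested is meant among the compounds shown, and "the series" means these compounds.

Compound 1 `Cc1cc(C)c(NC(=O)N(Cc2ccc(-c3nnc(C)o3)cc2)C2CCCCCC2)c(C)c1`: in a functional assay on a cell-free system (plasma) with sterol O-acyltransferase, Soat (Rattus norvegicus) as the target (a lower number here means that less compound is needed, a higher number that more compound is needed for the effect), compound 1 gives > 0.32 mg/kg, which is a limit rather than a number.
Compound 2 `Cc1cc(C)c(NC(=O)N(Cc2ccc(-c3cn[nH]c3)cc2)C2CCCCCC2)c(C)c1`: compound 2 gives > 1 mg/kg, also a limit.
Compound 3 `Cc1cc(C)c(NC(=O)N(Cc2ccc(-c3ccnn3C)cc2)C2CCCCCC2)c(C)c1`: compound 3 gives < 1 mg/kg, again a limit.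

Compound 3 thus stands only at a limit, and the two other values shown are limits as well (the limit of < 1 mg/kg in this assay, at which 1 of the 3 values shown sits). Compound 4 `Cc1cc(C)c(NC(=O)N(Cc2ccc(-n3ccnc3)cc2)C2CCCCCC2)c(C)c1` differs from compound 3 by 1H-imidazol-1-yl in place of 1-methyl-1H-pyrazol-5-yl on an aromatic carbon. The measured steps that touch compound 3, a step that the limit leaves unreadable from compound 1 to compound 3 and a number no higher from compound 2 to compound 3 (the limit leaves the size open), cannot be read in size because each end is a limit of > 0.32 mg/kg in this assay, at which 1 of the 3 values shown sits (the limit of > 1 mg/kg in this assay, at which 1 of the 3 values shown sits). Going by the values given here, no measured step matches the change to compound 4. The expectation for compound 4 is therefore a step of a number no lower from compound 3 to compound 4 (the limit leaves the size open), with no direction beyond the scatter. Compound 4 is estimated at 1 mg/kg, between 0.3 mg/kg and 3 mg/kg.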

Compound 4, dose for half-maximal effect: > 1 mg/kg
Compound 4 was reported as a limit; the forecaster's own chance of this, stated with the estimate: 60%; the middle value lies on the limit itself.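

In this assay, 1H-imidazol-1-yl in place of 1-methyl-1H-pyrazol-5-yl, para to a large group, gives a number no lower from compound 3 to compound 4 (the limit leaves the size open). Going by these compounds alone, this is the first change at this position that shows a direction, though only a limit-bound one, and the steps to compound 4 from compound 1 and compound 2 cannot be read in size at all. Compound 4 now stands with compound 2 at one shared limit: the limit of > 1 mg/kg in this assay, at which 2 of the 4 values shown sit.

On these data alone, the true size of any of these steps stays open. So does what a simple amine or a carboxylic acid at this position would give in this assay.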